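Working notes on compounds 1 to 3

The source may report more compounds than this note shows. Statements on the series, on what has been measured and on what is new or still open speak of the compounds shown alone.

Measured so far:
compound 1 `CN(C)C/C=C/C(=O)Nc1cccc(Nc2nc(N/N=C/c3ccc(F)cc3)ncc2Cl)c1` gives 3300 nM
compound 2 `CN(C)C/C=C/C(=O)Nc1cccc(Nc2nc(N/N=C/c3c[nH]c4ccccc34)ncc2Cl)c1` gives 9680 nM

Only these two values exist in an ADME assay on HT-29 cells (Homo sapiens) for inhibition, read by MTT assay, with a stated time of 72 h; a higher number here means a weaker inhibitor, a lower number a stronger inhibitor. Going by the values given here, compound 2 carries the highest number of the two; the sole step available, a 2.9-fold higher number from compound 1 to compound 2 (0.47 log units; beyond the scatter), separates it from compound 1.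

Compound 3 `C/C(=N\Nc1ncc(Cl)c(Nc2cccc(NC(=O)/C=C/CN(C)C)c2)n1)c1ccc(F)cc1` is not yet measured. Relative to compound 2 the change is a group of 10 heavy atoms (8 carbon, 1 nitrogen, 1 fluorine; one six-membered aromatic ring of carbon only) in place of a group of 11 heavy atoms (9 carbon, 2 nitrogen; one five-membered aromatic ring with 1 hetero atom, one six-membered aromatic ring of carbon only), on a nitrogen on an aromatic ring. Among the compounds with values here, this largely reverses the step from compound 1 to compound 2: the six-membered aromatic ring of carbon only with fluorine returns, and the entering group differs from that of compound 1 only at the carbon with a double bond to nitrogen, a detail no measured pair addresses. The bearing step is a 2.9-fold higher number from compound 1 to compound 2 (0.47 log units; beyond the scatter), modest but beyond the scatter. The expectation for compound 3 is therefore a lower number, back toward compound 1, as a 2.4-fold lower number from compound 2 to compound 3 (0.38 log units; beyond the scatter). Compound 3 is estimated at 4000 nM, range 1500 nM to 10000 nM.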

Compound 3, half-maximal inhibitory concentration: 10200 nM
The estimate for compound 3 lay 2.6-fold (0.41 log units) below the measured number; the whole stated range lies below it.
By their numbers in this assay, from the lowest: compound 1; then compounds 2 and 3 (each within the scatter of the next).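

In this assay the 4-fluorophenyl ring alone does not set the number at this place on a nitrogen on an aromatic ring: the group of 10 heavy atoms in place of the group of compound 1 gives a 3.1-fold higher number from compound 1 to compound 3 (0.49 log units; beyond the scatter) and so the difference at the carbon with a double bond to nitrogen is enough to separate two groups that share that ring. With a 1.1-fold higher number from compound 2 to compound 3 (0.02 log units; within the scatter) as the other step, the group of compound 3 and the 1H-indol-3-yl group of compound 2 cannot be told apart here, and only compound 1 stands apart from the other two.

The compounds shown leave open how an ethyl group on that carbon, or an amine or a carboxylic acid on the ring, would read in this assay on this core. Nothing available explains these differences.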